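Spiro amide series: aminopyridine for pyridine, lipophilicity notes

The source may hold more compounds than are shown below. What is called first, only, known or untested is meant among the compounds shown, and "the series" means these compounds.

Of the compounds shown here, three of the shared core have been measured in a physicochemical assay for lipophilicity, read by HPLC, measured as octanol-water partition, at pH 7.4; a lower number here means a more polar compound, a higher number a more lipophilic compound. Compound 1 `CC1(C)Cc2c(CN3CCC4(CC3)CCN(C(=O)c3ccncc3)CC4)cccc2O1` gives 1.6. Compound 3 `COc1ccccc1Oc1cccc(CN2CCC3(CC2)CCN(C(=O)c2ccncn2)CC3)c1` gives 1.7, a value within the scatter of compound 1, so no order between these two can be read. Compound 2 `CC1(C)CCc2cc(CN3CCC4(CC3)CCN(C(=O)c3ccncn3)CC4)ccc2O1` gives 0.9, which lies below compound 1 by more than the scatter. Compound 1 thus stands second highest of the three numbers, with compound 3 nearest and compound 2 furthest.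

Compound 4 `CC1(C)Cc2c(CN3CCC4(CC3)CCN(C(=O)c3ccc(N)cn3)CC4)cccc2O1` has not yet been measured. It differs from compound 1 in one place: 5-aminopyridin-2-yl in place of pyridin-4-yl on a carbonyl carbon. Going by the values given here, no measured pair shows this same change, so the size of the step cannot be taken from the series itself. A decrease in this assay is expected, of modest size and probably just beyond the scatter. The expected step is a number 0.50 log units lower from compound 1 to compound 4 (beyond the scatter). Compound 4 is estimated at 1.1, within a range from 0.6 to 1.6.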

Compound 4, distribution coefficient: 1.3
The estimate for compound 4 lay 0.20 log units below the measured number; the measured number falls inside the stated range.
By their numbers in this assay, from the lowest: compound 2; then compounds 4, 1 and 3 (each within the scatter of the next, the first and the last beyond it).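

The swap of pyridin-4-yl for 5-aminopyridin-2-yl on a carbonyl carbon gives the series its first single-place comparison, and it reads as a number 0.30 log units lower from compound 1 to compound 4 (within the scatter) in this assay. The entering group has 1 hydrogen-bond donor and 2 hydrogen-bond acceptors against 0 and 1 for the leaving group, yet this change does not separate compound 4 from compound 1 in this assay. No measurement bearing on the reason for this result is available.

Open, as far as these compounds go, is how much of this step belongs to the change of ring attachment and how much to the amino group, which a plain pyridin-2-yl on the same carbonyl carbon would separate. Also open, from the compounds shown here alone, is whether a 5-(dimethylamino)pyridin-2-yl or a 5-carboxypyridin-2-yl at that place would stay within the scatter of compound 1.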